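The compounds below may be only part of what the source reports. "The series", "measured", "known", "first", "only" and "open" are said of these compounds alone.

Within the data shown here, compound 3 `Cc1nc(-c2ccc(Cl)cc2)sc1COc1ccc2c(c1)OCC2CC(=O)O` gives 53.4% in a functional assay on CHO cells for agonist activity at Free fatty acid receptor 1 (Homo sapiens), read by FLIPR and calcium flux, tested at 100 nM (a lower number here means a weaker effect, a higher number a stronger effect of the compound at the concentration tested), the highest of the three numbers measured so far. Compound 1 `Cc1cccc(-c2nc(C)c(COc3ccc4c(c3)OCC4CC(=O)O)s2)c1` gives 47.2% in this assay, and the step of a number 6.2 percentage points higher from compound 1 to compound 3 (within the scatter) lies within the scatter, so these two are not told apart. Compound 2 `Cc1nc(-c2cccc(Cl)c2)sc1COc1ccc2c(c1)OCC2CC(=O)O` gives 43% in this assay, and the step of a number 10.4 percentage points higher from compound 2 to compound 3 (beyond the scatter) is beyond the scatter, though modest.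

Compound 4 `COc1ccc(-c2nc(C)c(COc3ccc4c(c3)OCC4CC(=O)O)s2)cc1` differs from compound 3 in one place: methoxy in place of chloro on an aromatic carbon. Among the measured compounds shown here, no measured step exchanges chloro for methoxy, so the bearing steps are those that swap a substituent on the same phenyl ring. The step of a number 4.2 percentage points lower from compound 1 to compound 2 (within the scatter) stayed within the scatter, and the step of a number 10.4 percentage points higher from compound 2 to compound 3 (beyond the scatter) was modest. Neither suggests that a single substituent on this ring moves this assay by much, so the expected step for compound 4 is small, with no clear direction, and is estimated as a number 7.4 percentage points lower from compound 3 to compound 4 (within the scatter).

Compound 4 is therefore expected to give about 46% in this assay, with a range from 30% to 60%.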

Compound 4, a percentage reported as activity, at one concentration (the size of the read-out at that concentration, not a potency): 46.8%
For compound 4 the middle estimate is 0.8 percentage points below the measured one, within the range that was stated.
By their numbers in this assay, from the lowest: compounds 2, 4, 1 and 3 (each within the scatter of the next, the first and the last beyond it).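

In this assay, the change from 4-chlorophenyl to 4-methoxyphenyl, with two heavy atoms and a hydrogen-bond acceptor entering para to a large group where a single chlorine left, gives a number 6.6 percentage points lower from compound 3 to compound 4 (within the scatter) and so does not separate the two compounds. Among these compounds, compound 4 is also not told apart from the two compounds with the substituent placed differently on the phenyl ring, with a number 3.8 percentage points higher from compound 2 to compound 4 (within the scatter) and a number 0.4 percentage points lower from compound 1 to compound 4 (within the scatter) as the steps, which leaves a number 10.4 percentage points higher from compound 2 to compound 3 (beyond the scatter) as the only modest separation among the four and the one pair that goes against a reading of this ring as wholly insensitive to its substituent. No evidence is available that would explain these numbers.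

The compounds shown leave open whether an amine, a carboxylic acid or a longer chain such as butoxy in this same place would move the number beyond the scatter. They also leave open whether 3-methoxyphenyl would stand apart from 4-methoxyphenyl as 3-chlorophenyl does from 4-chlorophenyl.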